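The source may report more compounds than this note shows. Statements on the series, on what has been measured and on what is new or still open speak of the compounds shown alone.

Of the compounds shown here, two built on one shared core have been tested in a functional assay on MCF7 cells (Homo sapiens) for antiproliferative activity, read by MTT assay, with a stated time of 48 h; on this read-out lower numbers stand for stronger inhibition and higher numbers for weaker inhibition. Compound 1, `N#CC1=C(N)Oc2c(c3nc4ccccc4nc3c3ccccc23)C12C(=O)N(Cc1cnnn1-c1ccc([N+](=O)[O-])cc1)c1ccccc12`, gives > 50000 nM, and that value is a limit of the assay rather than a measured number. Compound 2, `COc1ccccc1-n1nncc1CN1C(=O)C2(C(C#N)=C(N)Oc3c(N)cc4nc5ccccc5nc4c32)c2ccccc21`, gives 28900 nM in this assay. Among the two values shown, that of compound 2 is the only actual number; the other value is the limit of > 50000 nM in this assay, at which 1 of the 2 values shown sits. Compound 2 is therefore the one fixed point from which to look ahead.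

Compound 3, `Cc1ccc(Cl)cc1-n1nncc1CN1C(=O)C2(C(C#N)=C(N)Oc3c(N)cc4nc5ccccc5nc4c32)c2ccccc21`, has not yet been measured in this assay. It differs from compound 2 in a single place: 5-chloro-2-methylphenyl in place of 2-methoxyphenyl on an aromatic nitrogen. Among the measured compounds shown here, no pair of measured compounds differs by such a swap, so there is no measured step to lean on. The expectation here is a step from compound 2 of a 1.2-fold lower number from compound 2 to compound 3 (0.06 log units; within the scatter), that is, nothing beyond the usual scatter of repeated measurements. On that basis compound 3 is expected to give about 25000 nM in this assay, with a plausible span from 8000 nM to 80000 nM.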

Compound 3, half-maximal inhibitory concentration: 43500 nM
The estimate for compound 3 lay 1.7-fold (0.24 log units) below the measured number, and the stated range covers the measured number.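

Among the compounds shown here, the first step that can be read at this position is a 1.5-fold higher number from compound 2 to compound 3 (0.18 log units; within the scatter) in this assay, for 5-chloro-2-methylphenyl in place of 2-methoxyphenyl on an aromatic nitrogen. The group that leaves carries a hydrogen-bond acceptor and the group that enters carries none, yet this exchange gives no difference that can be told from the usual scatter of repeated measurements. Compound 1 remains a limit of the assay and not a number, so it adds no measured step here: the limit of > 50000 nM in this assay, at which 1 of the 3 values shown sits.

The compounds shown leave open whether a different kind of group on this aromatic nitrogen, such as a phenyl ring bearing an amine or a carboxylic acid, or a plain alkyl chain in place of the phenyl ring, would move the number beyond the scatter. Also open, from the compounds shown here alone, is what the chlorine and the methyl each do alone, for the two enter together in this single step.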